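Aryl swap on the enamine nitrogen of the pyrrolinone series

The source may report more compounds than this note shows. Statements on the series, on what has been measured and on what is new or still open speak of the compounds shown alone.

Measured so far in a functional assay on U2OS cells (Homo sapiens) for antiproliferative activity, read by MTT assay, with a stated time of 72 h; on this read-out higher numbers stand for weaker inhibition and lower numbers for stronger inhibition:
- compound 1 `CC(C)OC1=C(C(=O)c2ccccc2)C(c2ccc(Br)cc2)N(CCCn2ccnc2)C1=O` gives 24800 nM
- compound 2 `NC1=C(C(=O)c2ccccc2)C(c2ccc(Br)cc2)N(CCCn2ccnc2)C1=O` gives 149000 nM
- compound 3 `CCOc1ccc(NC2=C(C(=O)c3ccccc3)C(c3ccc(Br)cc3)N(CCCn3ccnc3)C2=O)cc1` gives 26200 nM

Compound 3 stands second highest of the three numbers; its nearest neighbour is compound 1, and the two are separated only by a 1.1-fold higher number from compound 1 to compound 3 (0.02 log units; within the scatter), which is within the scatter. Compound 2 is the furthest, as seen in a 5.7-fold lower number from compound 2 to compound 3 (0.75 log units; beyond the scatter), a modest step beyond the scatter.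

Compound 4 `O=C(C1=C(Nc2cccc(Br)c2)C(=O)N(CCCn2ccnc2)C1c1ccc(Br)cc1)c1ccccc1` differs from compound 3 by 3-bromophenyl in place of 4-ethoxyphenyl on an amine nitrogen. Among the measured compounds shown here, two measured steps touch this position. Going from the free amine to the arylated amine, a 5.7-fold lower number from compound 2 to compound 3 (0.75 log units; beyond the scatter), gave a modest drop, whereas a 1.1-fold higher number from compound 1 to compound 3 (0.02 log units; within the scatter) showed that the arylamino and isopropoxy substituents are indistinguishable here. For the measured compounds named here, no measured step compares one aryl group on this nitrogen with another, so there is no direct precedent for exchanging 4-ethoxyphenyl for 3-bromophenyl. Since the arylated amine of compound 3 is the closer model, a step of a 1.0-fold lower number from compound 3 to compound 4 (0.02 log units; within the scatter) is expected, that is, nothing beyond the scatter. Compound 4 is therefore estimated at 25000 nM, within 10000 nM to 65000 nM.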

Compound 4, half-maximal inhibitory concentration: 11900 nM
Estimate against measurement, compound 4: 2.1-fold (0.32 log units) above; the measured number falls inside the stated range.
By their numbers in this assay, from the lowest: compound 4; then compounds 1 and 3 (each within the scatter of the next); then compound 2.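

In this assay, among the compounds shown here, the first comparison of one aryl group with another on this amine nitrogen gives a 2.2-fold lower number from compound 3 to compound 4 (0.34 log units; beyond the scatter), so the identity of the aryl group moves the number, and not only its presence. The (3-bromophenyl)amino group also separates from isopropoxy, with a 2.1-fold lower number from compound 1 to compound 4 (0.32 log units; beyond the scatter), whereas (4-ethoxyphenyl)amino stayed within the scatter of isopropoxy. Measured from the free amine, the step with 3-bromophenyl is large, at a 13-fold lower number from compound 2 to compound 4 (1.10 log units; beyond the scatter), where the one with 4-ethoxyphenyl was modest. Nothing available accounts for the gap between the two aryl groups. Open, on these data alone, is whether the bromine, its place on the ring or the loss of the ethoxy carries the step; an unsubstituted phenyl or a 4-bromophenyl on this nitrogen would separate these.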